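Swapping the Ring on a Sulfonyl Sulfur

The compounds below may be only part of what the source reports. "The series", "measured", "known", "first", "only" and "open" are said of these compounds alone.

Going by the values given here, in a toxicity assay on HepG2 cells (Homo sapiens) for cytotoxicity, read by MTT assay, with a stated time of 48 h (on this read-out higher numbers stand for lower toxicity in this test and lower numbers for higher toxicity in this test), compound 2 `CN1CCCN(S(=O)(=O)c2ccc(-c3ccc4c(Nc5ccc(OCc6cccc(F)c6)c(Cl)c5)nncc4c3)cc2)CC1` gives 3.4 uM as the only true number among the three compounds tested. Compound 1 `O=S(=O)(c1ccc(-c2ccc3c(Nc4ccc(OCc5ccccc5)c(Cl)c4)nncc3c2)cc1)N1CCOCC1` gives > 15 uM as a limit of the assay and not a number. Compound 3 `CN1CCN(S(=O)(=O)c2ccc(-c3ccc4ccnc(Nc5ccc(OCc6cccc(F)c6)c(Cl)c5)c4c3)cc2)CC1` gives > 15 uM as a limit of the assay as well. Among the compounds with values here, compound 2 therefore stands alone as the one compound with a measured value in this assay and offers the only firm starting point.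

Compound 4 `CN1CCN(S(=O)(=O)c2ccc(-c3ccc4c(Nc5ccc(OCc6cccc(F)c6)c(Cl)c5)nncc4c3)cc2)CC1` has not yet been measured. It shares its core with compound 2 and differs by a single change 4-methylpiperazin-1-yl in place of 4-methyl-1,4-diazepan-1-yl on a sulfonyl sulfur that places 4-methylpiperazin-1-yl in place of 4-methyl-1,4-diazepan-1-yl on a sulfonyl sulfur. Within the data shown here, no pair of measured compounds differs in one place only, and the size of this step can only be estimated. The expectation leans on compound 3, which carries the same 4-methylpiperazin-1-yl on a different core and reads > 15 uM as a limit. The expected step is a 2.4-fold higher number from compound 2 to compound 4 (0.37 log units; beyond the scatter) and it is expected to be modest, pointing towards lower toxicity in this test. Compound 4 is estimated at 8 uM with an expected range from 3 uM to 15 uM and the reading may yet come back as a limit.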

Compound 4, half-maximal toxic concentration: > 15 uM
Compound 4: no number, only a limit; the forecaster's own chance of this, stated with the estimate: 30%; middle value at least 1.8-fold (0.27 log units) from the limit.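

In this assay the change on the sulfonyl sulfur gives an at least 4.4-fold higher number from compound 2 to compound 4 (0.64 log units; beyond the scatter) and points towards lower toxicity in this test. Going by these compounds alone, this is the first step in the set that can be read at a single place, since no two of compound 1, compound 2 and compound 3 differ in one place only. It shows that, on the shared core, this position matters for the read-out: exchanging 4-methyl-1,4-diazepan-1-yl for 4-methylpiperazin-1-yl is enough to move the reading from a measured number to a limit of the assay, so the true size of the step remains unknown because the reading stops at the limit: the limit of > 15 uM in this assay, at which 3 of the 4 values shown sit.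

The compounds shown leave open whether a pyrrolidin-1-yl ring or an open-chain dimethylamino group on the same sulfonyl sulfur would return a measured number in this assay or also reach the limit. They also leave open whether a 2-hydroxyethyl chain in place of the methyl group on 4-methylpiperazin-1-yl would change the reading on this core.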